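The compounds below may be only part of what the source reports. "The series", "measured", "known", "first", "only" and "open" are said of these compounds alone.

Three compounds have been measured in an ADME assay on cells (Fibroblast) for cytotoxicity; on this read-out lower numbers stand for stronger inhibition and higher numbers for weaker inhibition:

Compound 1 `CN(C)c1ccc(C(=O)N[C@@H](CSCCCC(=O)NO)C(=O)Nc2ccc(-c3ccccc3)cc2)cc1`: 320 nM
Compound 2 `O=C(/C=C/c1ccccc1)N[C@@H](CCCCCC(=O)NO)C(=O)Nc1cccc2cccnc12`: 1240 nM
Compound 3 `O=C(/C=C/c1ccccc1)N[C@@H](CCCCCC(=O)NO)C(=O)NCc1ccccc1`: 4010 nM

Compound 2 stands in the middle of these three numbers. Among the measured compounds shown here, only compound 1 lies lower, and the one measured step, a 3.2-fold higher number from compound 2 to compound 3 (0.51 log units; beyond the scatter), leads upward. Compound 4 `CN(C)c1ccc(C(=O)N[C@@H](CCCCCC(=O)NO)C(=O)Nc2cccc3cccnc23)cc1` departs from compound 2 in a single place: 4-(dimethylamino)phenyl in place of 2-phenylethenyl on a carbonyl carbon. In short, 4-(dimethylamino)phenyl stands in place of 2-phenylethenyl on a carbonyl carbon.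

For the measured compounds named here, no measured step covers this change. The step above concerns benzyl in place of quinolin-8-yl on an amide-type nitrogen, so it does not bear directly on it. Compound 1 also carries 4-(dimethylamino)phenyl on a carbonyl carbon and gives 320 nM, but it differs from compound 2 elsewhere too, which leaves only a weak hint towards a lower number. No step beyond the scatter is therefore expected in this assay. The expected change is a 1.2-fold lower number from compound 2 to compound 4 (0.09 log units; within the scatter). For compound 4 the estimated value is 1000 nM, with an expected range from 350 nM to 3000 nM.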

Compound 4, half-maximal inhibitory concentration: 570 nM
Estimate against measurement, compound 4: 1.8-fold (0.24 log units) above; the measured number falls inside the stated range.
By their numbers in this assay, from the lowest: compounds 1 and 4 (each within the scatter of the next); then compound 2; then compound 3.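

In this assay, the group on the carbonyl carbon moves the number by itself: with the rest of compound 2 unchanged, 4-(dimethylamino)phenyl in place of 2-phenylethenyl gives a 2.2-fold lower number from compound 2 to compound 4 (0.34 log units; beyond the scatter), a step beyond the scatter. Among the compounds shown here, this is the first measured step at this position, and it runs downward, whereas the only earlier step, a 3.2-fold higher number from compound 2 to compound 3 (0.51 log units; beyond the scatter), concerned the amide-type nitrogen and ran upward. Nothing available explains why the number moves with this change.

The compounds shown leave open which part of the change matters, the loss of the double bond outside aromatic rings or the arrival of the dimethylamino group, and a plain phenyl on the same carbonyl carbon would separate the two. They also leave open whether the step holds with benzyl on the amide-type nitrogen.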